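Swapping the benzyl substituent on a modified adenine nucleoside

This account rests on a few compounds, and the source may have more. Where it says the series, first, only, none or still open, it means among the compounds named here.

The series rests on a shared core, carried by compound 1 `Nc1ncnc2c1ncn2[C@@H]1OC[C@](O)(CO)[C@H]1O`. In an assay on CHO cells for displacement of a labelled ligand from adenosine receptor A1 (Homo sapiens), tested at 10 uM (on this read-out lower numbers stand for less inhibition and higher numbers for more inhibition at the one concentration tested (going by the name of the read-out)), compound 1 gives 6%. Compound 2 `COc1ccc(Cl)cc1CNc1ncnc2c1ncn2[C@@H]1OC[C@](O)(CO)[C@H]1O` bears a 5-chloro-2-methoxyphenyl group on the saturated chain carbon bound to the ring nitrogen, and in this assay compound 2 gives 12%. That is the higher of the two numbers recorded, but compound 1 lies within the scatter of it, so the two show no real difference.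

Compound 3 `OC[C@@]1(O)CO[C@@H](n2cnc3c(NCc4cccc(I)c4)ncnc32)[C@@H]1O` has not been measured. It differs from compound 2 as follows (3-iodophenyl in place of 5-chloro-2-methoxyphenyl on a saturated chain carbon bound to a nitrogen on an aromatic ring). Among the compounds with values here, no step between measured compounds covers this exchange. Given that compound 2 reads 12%, the step is expected to be small, at most a modest rise, and stays within the scatter: a number 6 percentage points higher from compound 2 to compound 3 (within the scatter). Compound 3 is estimated at 18%, with a range from 2% to 42%.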

Compound 3, a percentage reported as inhibition, at one concentration (the size of the read-out at that concentration, not a potency): 27%
Compound 3: middle estimate off by 9 percentage points, on the low side; measured number inside the range.
By their numbers in this assay, from the lowest: compounds 1 and 2 (each within the scatter of the next); then compound 3.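

In this assay, 3-iodophenyl in place of 5-chloro-2-methoxyphenyl on a saturated chain carbon bound to a nitrogen on an aromatic ring gives a step beyond the scatter (a number 15 percentage points higher from compound 2 to compound 3 (beyond the scatter)), so the aryl group at this place can change the read-out, which the pair of compound 1 and compound 2 could not show. Against hydrogen on the nitrogen, the 3-iodobenzyl group also clears the scatter (a number 21 percentage points higher from compound 1 to compound 3 (beyond the scatter)), whereas the 5-chloro-2-methoxyphenyl group of compound 2 could not be told apart from compound 1. Nothing at hand accounts for the rise.

Going by these compounds, whether the rise goes with the iodine or with the loss of the chlorine and the methoxy stays open, as does what a 3-bromophenyl group or a plain phenyl group would read at this place. A single concentration also leaves the potency of compound 3 unknown.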